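This account rests on a few compounds, and the source may have more. Where it says the series, first, only, none or still open, it means among the compounds named here.

Measured compounds in a functional assay on NCI-H226 cells (Homo sapiens) for cytotoxicity, read by sulforhodamine B assay, with a stated time of 48 h, tested at 0.01 uM; on this read-out higher numbers stand for a weaker effect at the one concentration tested and lower numbers for a stronger effect:

- compound 1 `COc1cc(-c2cc(/C=C/C(=O)c3ccc(Cl)c(Cl)c3)[nH]n2)cc(OC)c1OC` gives 103%
- compound 2 `COc1ccc(C(=O)/C=C/c2cc(-c3cc(OC)c(OC)c(OC)c3)n[nH]2)cc1` gives 99%
- compound 3 `COc1ccc(C(=O)/C=C/c2cc(-c3cc(OC)c(OC)c(OC)c3)n[nH]2)cc1OC` gives 98%

Compound 3 holds the lowest of the three numbers, but the gap to compound 2, a number 1 percentage points lower from compound 2 to compound 3 (within the scatter), and the gap to compound 1, a number 5 percentage points lower from compound 1 to compound 3 (within the scatter), both sit within the scatter, so the three compounds are not separated on this read-out.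

Compound 4 `COc1cc(-c2cc(/C=C/C(=O)c3ccc(F)c(F)c3)[nH]n2)cc(OC)c1OC` differs from compound 3 by 3,4-difluorophenyl in place of 3,4-dimethoxyphenyl on a carbonyl carbon. Within the data shown here, the steps that bear on this are the two earlier exchanges of the aryl group on the carbonyl carbon, a number 4 percentage points lower from compound 1 to compound 2 (within the scatter) and a number 5 percentage points lower from compound 1 to compound 3 (within the scatter), each within the scatter. On that basis the step of a number 2 percentage points higher from compound 3 to compound 4 (within the scatter) is expected to stay within the scatter, with no direction beyond it.

Compound 4 is therefore estimated at 100% in this assay, within 90% to 110%.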

Compound 4, a percentage reported as activity, at one concentration (the size of the read-out at that concentration, not a potency): 99%
Compound 4: the middle estimate sits 1 percentage points above what was measured, and the stated range covers the measured number.
By their numbers in this assay, from the lowest: compounds 3, 2, 4 and 1 (each within the scatter of the next).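

In this assay, 3,4-difluorophenyl on the carbonyl carbon gives no separation from the other aryl groups: a number 1 percentage points higher from compound 3 to compound 4 (within the scatter), no change at the digits printed from compound 2 to compound 4 (within the scatter) and a number 4 percentage points lower from compound 1 to compound 4 (within the scatter). Exchanging 3,4-dimethoxyphenyl, with its hydrogen-bond acceptors, for 3,4-difluorophenyl, which has none, therefore leaves the read-out within the scatter at this one concentration. No measured evidence bearing on this result is available.

Still open, going by these compounds, is whether any group on this carbonyl carbon separates from these aryl groups, for example an aminophenyl or a carboxyphenyl group, or a longer chain in place of the aryl ring.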